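Isopropyl in place of dimethylamino on a carbonyl carbon

A few compounds are considered here, and "the series" means these few. Any claim that something is new, unique, unknown or untested is made for them only; others in the source may bear on it.

Compound 1 `O=C(CCO)N[C@@H](CO)C(=O)O` gives 96%
Compound 2 `CN(C)C(=O)N[C@@H](CO)C(=O)O` gives 34%

In an ADME assay on microsomes from liver (Homo sapiens) for metabolic stability, with a stated time of 30 min (on this read-out higher numbers stand for a more stable compound and lower numbers for a less stable compound), compound 2 stands lowest of the two measured compounds. Compound 3 `CC(C)C(=O)N[C@@H](CO)C(=O)O` carries isopropyl in place of dimethylamino on a carbonyl carbon. Among the measured compounds shown here, only one measured step bears on this place: a number 62 percentage points lower from compound 1 to compound 2 (beyond the scatter), with dimethylamino in place of 2-hydroxyethyl. For the measured compounds named here, no measured compound carries isopropyl, so part of that large step is expected to return, with wide uncertainty. The expected change is a number 26 percentage points higher from compound 2 to compound 3 (beyond the scatter), a moderate to large rise. Compound 3 is estimated at 60% (range 30% to 92%) in this assay for now.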

Compound 3, percent of the compound remaining: 84%
Beside the measured number, compound 3's estimate is 24 percentage points below it; the range from low to high includes it.
By their numbers in this assay, from the lowest: compound 2; then compound 3; then compound 1.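

Isopropyl in place of dimethylamino on a carbonyl carbon gives a number 50 percentage points higher from compound 2 to compound 3 (beyond the scatter) in this assay, although both groups have the same heavy-atom count and no hydrogen-bond donors or acceptors. Isopropyl in place of 2-hydroxyethyl gives only a number 12 percentage points lower from compound 1 to compound 3 (beyond the scatter), so among these three compounds the low number belongs to the dimethylamino compound alone. No available information bears on the cause of these steps.

Still open, as far as these compounds go, is whether a single methylamino group on this carbonyl carbon would track dimethylamino, and whether a tert-butyl group or a longer chain would track isopropyl.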